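Sulfonamide Changes on a Shared Core: Methyl to Chloro

The compounds below may be only part of what the source reports. "The series", "measured", "known", "first", "only" and "open" are said of these compounds alone.

Compound 1 `O=S(=O)(Nc1ccc(-c2nc3ccccc3o2)cc1)c1ccc(F)c(C(F)(F)F)c1`: 28000 nM
Compound 2 `O=S(=O)(Nc1ccc2oc(-c3ccccc3)nc2c1)c1ccccc1O`: 85000 nM
Compound 3 `Cc1ccccc1S(=O)(=O)Nc1ccc2oc(-c3ccccc3)nc2c1`: > 100000 nM

In an assay on cells for inhibition of HSP60/HSP10 (Homo sapiens), with a stated time of 60 min (a higher number here means a weaker inhibitor, a lower number a stronger inhibitor), compound 1 gives 28000 nM and compound 2 gives 85000 nM. For compound 3 the assay reports only a limit, > 100000 nM. Compound 3 therefore stands at the limit of > 100000 nM in this assay, at which 1 of the 3 values shown sits, reached through the step of an at least 1.1-fold higher number from compound 2 to compound 3 (0.07 log units; that floor lies within the scatter). Compound 4 `O=S(=O)(Nc1ccc2oc(-c3ccccc3)nc2c1)c1ccccc1Cl` differs from compound 3 by chloro in place of methyl on an aromatic carbon. Going by the values given here, no measured step swaps methyl for chloro, so none bears directly on this change; the single step into compound 3 shows only that it ended at the limit. The expected step is a number no higher from compound 3 to compound 4 (the limit leaves the size open), nothing beyond the scatter. Compound 4 is thus expected at 100000 nM, within 30000 nM to 300000 nM, most likely again as a limit.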

Compound 4, half-maximal inhibitory concentration: > 100000 nM
Compound 4 gave a limit, no number (the forecaster's own chance of this, stated with the estimate: 60%); the middle value sits exactly at the limit.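

Chloro, like methyl, leaves the compound at a limit of this assay rather than giving a number, so two different groups at this position now end there: the limit of > 100000 nM in this assay, at which 2 of the 4 values shown sit. The step between compound 3 and compound 4 cannot be read, and swapping hydroxy for chloro gives an at least 1.1-fold higher number from compound 2 to compound 4 (0.07 log units; that floor lies within the scatter).

Going by these compounds, on this shared core, only the hydroxy of compound 2 gives a number at this position, so it remains open whether chloro and methyl differ at all. Also open, on these data alone, is how an amine or a carboxylic acid would read here.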